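Putting a triple bond into the side chain

The source may hold more compounds than are shown below. What is called first, only, known or untested is meant among the compounds shown, and "the series" means these compounds.

Of the compounds shown here, three sharing one core have been tested in a functional assay on A-375 cells (Homo sapiens) for inhibition, read by MTT assay, with a stated time of 120 h; a higher number here means a weaker inhibitor, a lower number a stronger inhibitor. Compound 1 `CC(NC(=O)C#Cc1ccc(NC(=O)Nc2ccc(Cl)c(C(F)(F)F)c2)cc1)c1ccccc1` gives 16800 nM. Compound 2 `CNC(=O)c1cccc(-c2ccc(NC(=O)Nc3ccc(Cl)c(C(F)(F)F)c3)cc2)c1` gives 46500 nM. Compound 3 `CNC(=O)CCc1ccc(NC(=O)Nc2ccc(Cl)c(C(F)(F)F)c2)cc1` gives 25200 nM, which lies within the usual scatter of the values of both other compounds.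

Compound 4 `CNC(=O)C#Cc1ccc(NC(=O)Nc2ccc(Cl)c(C(F)(F)F)c2)cc1` has not yet been measured. It differs from compound 3 in one place, on an aromatic carbon of a six-membered aromatic ring of carbon only, para to a large group: 2-(methylcarbamoyl)ethynyl in place of 2-(methylcarbamoyl)ethyl on an aromatic carbon. In words, 2-(methylcarbamoyl)ethynyl stands in place of 2-(methylcarbamoyl)ethyl.

Among the measured compounds shown here, one measured step touches this same group, a 1.8-fold lower number from compound 2 to compound 3 (0.27 log units; within the scatter), and there 2-(methylcarbamoyl)ethyl came in for 3-(methylcarbamoyl)phenyl. Even that larger swap stayed within the scatter. Compound 1 already carries a triple bond in its chain, and its 16800 nM also lies within the scatter of the value of compound 3. For the measured compounds named here, no measured pair isolates the triple bond itself, so this remains indirect evidence.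

No change beyond the scatter is therefore expected in this assay. The expected step is small: a 1.3-fold lower number from compound 3 to compound 4 (0.10 log units; within the scatter). For compound 4 the estimated value is 20000 nM, with an expected range from 9000 nM to 45000 nM.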

Compound 4, half-maximal inhibitory concentration: > 50000 nM
Compound 4 gave a limit, no number; the forecaster's own chance of this, stated with the estimate: 10%; middle value at least 2.5-fold (0.39 log units) away from the limit.
By their numbers in this assay, from the lowest: compounds 1, 3 and 2 (each within the scatter of the next, the first and the last beyond it). At a limit, above all of these: compound 4.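

In this assay compound 4 gave a limit and not a number: the limit of > 50000 nM in this assay, at which 1 of the 4 values shown sits.

Set against the two other compounds with a methyl amide, this limit gives only floors, an at least 1.9-fold higher number from compound 3 to compound 4 (0.29 log units; that floor lies within the scatter) and an at least 1.0-fold higher number from compound 2 to compound 4 (0.03 log units; that floor lies within the scatter), so 2-(methylcarbamoyl)ethynyl on this aromatic carbon cannot yet be said to differ from either 2-(methylcarbamoyl)ethyl or 3-(methylcarbamoyl)phenyl. Among the compounds shown here, the new information comes from the amide nitrogen, where both compounds keep the triple bond and methyl stands in place of 1-phenylethyl, giving an at least 2.9-fold higher number from compound 1 to compound 4 (0.47 log units; beyond the scatter); the earlier compounds could not show this, and it means that the triple bond alone does not fix the read-out, since the group on the amide nitrogen also counts in this chain.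

From the compounds shown here alone, the true size of the step from the saturated chain to the triple bond stays open, as the limit marks only a floor. Also open, going by these compounds, is how this chain would behave with a benzyl group on the amide nitrogen, or with a carboxylic acid in place of the methyl amide.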